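Aryl sulfonate series: iodo for isopropyl on the ester ring

The compounds below may be only part of what the source reports. "The series", "measured", "known", "first", "only" and "open" are said of these compounds alone.

Measured in a functional assay on MCF7 cells (Homo sapiens) for antiproliferative activity, read by sulforhodamine B assay, with a stated time of 48 h; a higher number here means a weaker inhibitor, a lower number a stronger inhibitor:
compound 1 `CCC(=O)Nc1ccc(S(=O)(=O)Oc2ccccc2I)cc1` gives 8100 nM
compound 2 `CCCCCC(=O)Nc1ccc(S(=O)(=O)Oc2ccccc2I)cc1` gives 10000 nM
compound 3 `CC(C)c1ccccc1OS(=O)(=O)c1ccc(NC(=O)NCCCCl)cc1` gives 7400 nM

Compound 3 gives the lowest of the three numbers, but its gaps to compound 1 and to compound 2 are both within the scatter, so the three compounds cannot be separated on these data. For the measured compounds named here, the one measured step, a 1.2-fold higher number from compound 1 to compound 2 (0.09 log units; within the scatter), concerns the chain and not the aryl ring. Going by the values given here, compound 4 `O=C(NCCCCl)Nc1ccc(S(=O)(=O)Oc2ccccc2I)cc1` differs from compound 3 by iodo in place of isopropyl on an aromatic carbon; no measured pair shows this change, and compounds 1 and 2 combine iodo with an amide rather than a urea. With nothing pointing either way, the expected step of a 1.0-fold higher number from compound 3 to compound 4 (0.01 log units; within the scatter) is none beyond the scatter. Compound 4 is estimated at 7500 nM (range 3000 nM to 20000 nM).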

Compound 4, half-maximal inhibitory concentration: 7600 nM
Compound 4: the middle estimate sits 1.0-fold (0.01 log units) below what was measured; measured number inside the range.
By their numbers in this assay, from the lowest: compounds 3, 4, 1 and 2 (each within the scatter of the next).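

In this assay, for the compounds shown here, the first direct reading at this aromatic carbon, iodo in place of isopropyl gives a 1.0-fold higher number from compound 3 to compound 4 (0.01 log units; within the scatter) and leaves 2-isopropylphenyl and 2-iodophenyl unseparated with the urea side chain held constant. With iodo held constant, (3-chloropropyl)amino in place of pentyl on the carbonyl carbon gives a 1.3-fold lower number from compound 2 to compound 4 (0.12 log units; within the scatter) and in place of ethyl gives a 1.1-fold lower number from compound 1 to compound 4 (0.03 log units; within the scatter), so neither change moves the number beyond the scatter. No evidence bears on these results.

From the compounds shown here alone, whether a methoxy group, an amine or a carboxylic acid on this aromatic carbon would give a step beyond the scatter remains open.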